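Fluoro for methyl on the sulfonyl ring of compound 4

The source may report more compounds than this note shows. Statements on the series, on what has been measured and on what is new or still open speak of the compounds shown alone.

Compound 1 `COc1cc(N(Cc2cccc(C)c2)S(=O)(=O)c2ccc(C)cc2)cc(OC)c1OC` gives 8580 nM in a functional assay on PC-3 cells (Homo sapiens) for inhibition, read by MTT assay, with a stated time of 48 h; on this read-out lower numbers stand for stronger inhibition and higher numbers for weaker inhibition.
Compound 2 `COc1cc(N(Cc2csc3ccc(Cl)cc23)S(=O)(=O)c2ccc(C)cc2)cc(OC)c1OC` gives 15300 nM in this assay.
Compound 3 `COc1cc(N(Cc2nc3ccccc3[nH]2)S(=O)(=O)c2ccc(C)cc2)cc(OC)c1OC` gives 3340 nM in this assay.

Compound 3 stands lowest of the three: the steps of a 2.6-fold lower number from compound 1 to compound 3 (0.41 log units; beyond the scatter) and a 4.6-fold lower number from compound 2 to compound 3 (0.66 log units; beyond the scatter) both lie beyond the scatter, whereas a 1.8-fold higher number from compound 1 to compound 2 (0.25 log units; within the scatter) lies within it. Compound 4 `COc1cc(N(Cc2nc3ccccc3[nH]2)S(=O)(=O)c2ccc(F)cc2)cc(OC)c1OC` differs from compound 3 by fluoro in place of methyl on an aromatic carbon. Within the data shown here, none of the measured steps touches this part of the molecule; each of them changes only the group on the saturated chain carbon bound to the sulfonamide nitrogen, and the (4-methylphenyl)sulfonyl group is the same in all three. Among the measured compounds shown here, no measured step therefore bears on this change, and no step beyond the scatter is expected in this assay; the expected step is a 1.0-fold higher number from compound 3 to compound 4 (0.01 log units; within the scatter). Compound 4 is accordingly estimated at 3400 nM, with a range from 1400 nM to 8500 nM.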

Compound 4, half-maximal inhibitory concentration: 7990 nM
The estimate for compound 4 lay 2.4-fold (0.37 log units) below the measured number; measured number inside the range.
By their numbers in this assay, from the lowest: compound 3; then compounds 4, 1 and 2 (each within the scatter of the next).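

In this assay there is a 2.4-fold higher number from compound 3 to compound 4 (0.38 log units; beyond the scatter) when fluoro replaces methyl on the aromatic carbon para to a large group. The earlier steps shown here changed only the group on the chain carbon, so this shows that the number also responds to a change on the sulfonyl ring, here with the 1H-benzimidazol-2-yl group held fixed. No measurement offered here explains this step. The compounds shown leave open how a methoxy, chloro or amine group would read at this position, and whether fluoro for methyl gives a similar step alongside the 3-methylphenyl group of compound 1.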